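Ring-nitrogen substituent and cell inhibition in the amide series

This account rests on a few compounds, and the source may have more. Where it says the series, first, only, none or still open, it means among the compounds named here.

Values in a functional assay on 143B cells (Homo sapiens) for inhibition, read by CCK-8 assay, with a stated time of 72 h, tested at 1 uM; a higher number here means more inhibition at the concentration tested (going by the name of the read-out), a lower number less inhibition:
compound 1 `COc1ccc(OC)c(N2C(=O)CSC2c2cccc(C(=O)NCCCCc3ccccc3)c2)c1`: 2%
compound 2 `CCN1C(=O)CSC1c1cccc(C(=O)NCCCCc2ccccc2)c1`: 40%
compound 3 `O=C(NCCCCc1ccccc1)c1cccc(C2OCC(=O)N2c2cccc(F)c2)c1`: 0%

Compound 2 stands highest of the three in this assay; compound 1 lies nearest and compound 3 furthest, both beyond the scatter. Among the measured compounds shown here, the one single-point step measured is a number 38 percentage points higher from compound 1 to compound 2 (beyond the scatter), so removing the 2,5-dimethoxyphenyl from the ring nitrogen in favour of ethyl raised inhibition sharply. For the measured compounds named here, compound 3, with a different five-membered ring and a 3-fluorophenyl on its nitrogen, gives 0%, but no single-point step connects it to compound 2.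

Compound 4 `O=C(NCCCCc1ccccc1)c1cccc(C2SCC(=O)N2c2ccccc2F)c1` is not yet measured. It differs from compound 2 as follows: 2-fluorophenyl in place of ethyl on an amide-type nitrogen in a ring. Going by the values given here, this runs the measured step in reverse, an aromatic group re-entering on the ring nitrogen where ethyl leaves, and the one relevant step, from compound 1 to compound 2, was large. A drop of similar size is therefore expected in this assay. For compound 4 the estimated step is a number 32 percentage points lower from compound 2 to compound 4 (beyond the scatter), landing near the values of compounds 1 and 3. Compound 4 is thus expected to give about 8%, within 0% to 25%.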

Compound 4, a percentage reported as inhibition, at one concentration (the size of the read-out at that concentration, not a potency): 59%
For compound 4 the middle estimate is 51 percentage points below the measured one, outside the stated range (above it).
By their numbers in this assay, from the lowest: compounds 3 and 1 (each within the scatter of the next); then compound 2; then compound 4.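

In this assay, an aromatic group on the ring nitrogen does not by itself lower inhibition: 2-fluorophenyl in place of ethyl gives a number 19 percentage points higher from compound 2 to compound 4 (beyond the scatter). The identity of the aromatic group matters greatly at this position, since 2-fluorophenyl in place of 2,5-dimethoxyphenyl gives a number 57 percentage points higher from compound 1 to compound 4 (beyond the scatter), so the low value of compound 1 cannot be read as a general penalty for aromatic groups here.

As far as these compounds go, it remains open whether the gain seen with compound 4 needs the fluorine at all, which a plain phenyl on the same nitrogen would test. A benzyl group, or a phenyl carrying an amine or a carboxylic acid, would show how far this position extends beyond the two aromatic groups compared here. Among the compounds shown here, nothing measured so far explains why these two aromatic groups differ so widely.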